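This account rests on a few compounds, and the source may have more. Where it says the series, first, only, none or still open, it means among the compounds named here.

Measured so far:
Compound 2 `N=C(N)c1ccc(-c2ccc(-c3ccc(Cl)cc3)s2)cc1F`: in a functional assay on IGROV-1 cells (Homo sapiens) for inhibition, read by sulforhodamine B assay, with a stated time of 48 h (on this read-out lower numbers stand for stronger inhibition of growth and higher numbers for weaker inhibition of growth), compound 2 gives 611 nM.
Compound 3 `COc1cc(OC)cc(-c2ccc(-c3ccc(C(=N)N)c(F)c3)s2)c1`: in this assay compound 3 gives 484 nM.
Compound 1 `N=C(N)c1ccc(-c2ccc(-c3cc(Cl)cc(Cl)c3)s2)cc1`: in this assay compound 1 gives "not determined" (no result reported), so no number is available for it.

On these numbers compound 2 stands level with compound 3: the gap between them falls within the scatter, so neither stands apart. Compound 4 `N=C(N)c1ccc(-c2ccc(-c3ccccc3)s2)cc1F` is compound 2 with a single change, (hydrogen in place of chloro on an aromatic carbon). Among the compounds with values here, no measured pair shows this change, so its size cannot be read from the data. A modest weakening is expected, somewhat beyond the scatter: the step of a 2.1-fold higher number from compound 2 to compound 4 (0.33 log units; beyond the scatter) is the estimate. Compound 4 is therefore expected to give 1300 nM, within a range from 500 nM to 3500 nM.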

Compound 4, concentration for 50% growth inhibition: 5290 nM
Beside the measured number, compound 4's estimate is 4.1-fold (0.61 log units) below it; the measured number lies above the stated range.
By their numbers in this assay, from the lowest: compounds 3 and 2 (each within the scatter of the next); then compound 4.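

In this assay, within the data shown here, this is the first pair that differs in one place, and it shows that this position matters: going from 4-chlorophenyl to phenyl gives an 8.7-fold higher number from compound 2 to compound 4 (0.94 log units; beyond the scatter) and so weaker inhibition of growth. A single chlorine atom, on an aromatic carbon para to a large group, therefore makes a clear difference to this result. As far as these compounds go, whether a bromo group or an amine on that same carbon would do as well as chloro remains open. Among these compounds, nothing measured so far says why this one atom counts for so much.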